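A few compounds are considered here, and "the series" means these few. Any claim that something is new, unique, unknown or untested is made for them only; others in the source may bear on it.

Measured so far:

Compound 1, `COc1ccccc1/C=C/C(=O)/C=C/c1ccc(OCc2cn(CCOc3cc(=O)oc4ccccc34)nn2)c(OC)c1` — 11%
Compound 2, `COc1ccc(/C=C/C(=O)/C=C/c2ccc(OCc3cn(CCCCCOc4cc(=O)oc5ccccc45)nn3)c(OC)c2)cc1` — "not active" (no number reported)
Compound 3, `COc1cc(/C=C/C(=O)/C=C/c2cc(OC)c(OC)c(OC)c2)ccc1OCc1cn(CCOc2cc(=O)oc3ccccc23)nn1` — 22%

In a functional assay on PC-3 cells (Homo sapiens) for inhibition, read by sulforhodamine B assay, with a stated time of 48 h, tested at 50 uM (a lower number here means less inhibition of growth, a higher number more inhibition of growth at the concentration tested), compound 3 gives 22%, the higher of the two numbers reported; compound 1 comes nearest, and the step of a number 11 percentage points higher from compound 1 to compound 3 (beyond the scatter) separates them. Compound 2 is reported in this assay as "not active" (no number reported), without a number.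

Compound 4, `COc1ccc(/C=C/C(=O)/C=C/c2ccc(OCc3cn(CCOc4cc(=O)oc5ccccc45)nn3)c(OC)c2)cc1OC`, differs from compound 3 in one place: hydrogen in place of methoxy on an aromatic carbon. Going by the values given here, no measured step removes a methoxy from this ring. Among the compounds with values here, the only step that bears on it is a number 11 percentage points higher from compound 1 to compound 3 (beyond the scatter), which added methoxy groups and raised inhibition modestly; taking one away is therefore expected to lower it slightly, by a step of a number 6 percentage points lower from compound 3 to compound 4 (within the scatter) that may lie within the scatter. Compound 4 is expected to give 16%, in the range 5% to 30%.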

Compound 4, percent growth inhibition at one concentration: 19%
Estimate against measurement, compound 4: 3 percentage points below; measured number inside the range.
By their numbers in this assay, from the lowest: compounds 1, 4 and 3 (each within the scatter of the next, the first and the last beyond it).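

In this assay the step of a number 3 percentage points lower from compound 3 to compound 4 (within the scatter) shows that hydrogen in place of methoxy on this aromatic carbon, which turns 3,4,5-trimethoxyphenyl into 3,4-dimethoxyphenyl, leaves the reading within the scatter. The step of a number 8 percentage points higher from compound 1 to compound 4 (within the scatter) also stays within it, so of the two rings only 3,4,5-trimethoxyphenyl stands beyond the scatter from 2-methoxyphenyl. Nothing available explains these readings.

On these data alone, whether an amine or a carboxylic acid on this aromatic carbon would keep, raise or lower the inhibition remains open. The compounds shown also leave open whether the methoxy groups on the other positions of this ring can be replaced in the same way.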